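This account rests on a few compounds, and the source may have more. Where it says the series, first, only, none or still open, it means among the compounds named here.

Compound 1: `C[C@]1(CN2CCc3nc(N4CCCCC4)ccc3C2)Cn2cc([N+](=O)[O-])nc2O1` — an ADME assay on Vero cells (Chlorocebus sabaeus) for cytotoxicity, read by MTT assay, with a stated time of 72 h; a higher number here means that more compound is tolerated, a lower number that less compound is tolerated: "not determined" (no result reported)
Compound 2: `C[C@]1(CN2CCc3nc(-c4ccccc4F)ccc3C2)Cn2cc([N+](=O)[O-])nc2O1` — > 32 ug/mL

The account follows the step from compound 2 to compound 3 `C[C@]1(CN2CCc3nc(-c4ccc(F)cc4F)ccc3C2)Cn2cc([N+](=O)[O-])nc2O1`. In this assay compound 2 gives > 32 ug/mL, and this is a limit of the assay rather than a number. Among the compounds with values here, compound 2 therefore stands at the limit of > 32 ug/mL in this assay, at which 1 of the 2 values shown sits, while compound 1 carries no result at all, so the two measured entries together give no single number and no step that could be compared.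

Compound 3 differs from compound 2 in one place:
fluoro in place of hydrogen on an aromatic carbon

Within the data shown here, with no measured step to draw on, the expected step in this assay is none beyond the usual scatter, and the estimate means a step that the limit leaves unreadable from compound 2 to compound 3. Since compound 2 sits at the limit of > 32 ug/mL in this assay, at which 1 of the 2 values shown sits, compound 3 is expected to return a limit as well rather than a single number. The estimate for compound 3 in this assay is 40 ug/mL, with a range from 16 ug/mL to 100 ug/mL.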

Compound 3, half-maximal cytotoxic concentration: 12.5 ug/mL
Beside the measured number, compound 3's estimate is 3.2-fold (0.51 log units) above it; measured number outside the range, below it.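

In this assay, the step at this position is the first that can be read among the compounds shown: adding a fluoro group to an aromatic carbon, meta to a fluoro group and para to a large group, gives an at least 2.5-fold lower number from compound 2 to compound 3 (0.40 log units; beyond the scatter). The change from 2-fluorophenyl to 2,4-difluorophenyl adds a single heavy atom, yet it is enough to carry the number beyond the usual scatter, in the direction of less compound being tolerated. The step is only a lower bound on the real change, because compound 2 stands at a limit of the assay and not at a number: the limit of > 32 ug/mL in this assay, at which 1 of the 3 values shown sits.

The compounds shown do not tell whether this lower number is specific to fluoro or would follow from any group placed on this aromatic carbon, and they give no reason for the drop. A chloro group, a methoxy group or an amine at the same place would separate these readings, and a second fluoro group set elsewhere on the ring would show whether the position itself matters.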